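A few compounds are considered here, and "the series" means these few. Any claim that something is new, unique, unknown or untested is made for them only; others in the source may bear on it.

Three compounds share one core and differ only in the amine joined to the amide-type nitrogen. Compound 1 `O=C(N[C@@H]1CCNC1)c1cc(-c2ccc(NS(=O)(=O)c3cccc(Cl)c3Cl)cc2)nc2[nH]ncc12` carries pyrrolidin-3-yl, and in an assay for inhibition of serine/threonine-protein kinase Sgk1 (Homo sapiens), with stated times of 30 min and 60 min, in the presence of a further agent that is not named here (a higher number here means a weaker inhibitor, a lower number a stronger inhibitor), compound 1 gives < 1 nM, which is a limit of the assay rather than a number. Compound 2 `O=C(NC1CCN(CC2CC2)C1)c1cc(-c2ccc(NS(=O)(=O)c3cccc(Cl)c3Cl)cc2)nc2[nH]ncc12` carries 1-(cyclopropylmethyl)pyrrolidin-3-yl, and in this assay compound 2 gives 1 nM. Compound 3 `CN1CC(NC(=O)c2cc(-c3ccc(NS(=O)(=O)c4cccc(Cl)c4Cl)cc3)nc3[nH]ncc23)C1` carries 1-methylazetidin-3-yl, and in this assay compound 3 gives < 1 nM, again a limit. The steps of a number no lower from compound 1 to compound 2 (the limit leaves the size open) and a number no higher from compound 2 to compound 3 (the limit leaves the size open) cannot be sized, as the limit of < 1 nM in this assay, at which 2 of the 3 values shown sit, shows. Compound 4 `CCN1CCC(CNC(=O)c2cc(-c3ccc(NS(=O)(=O)c4cccc(Cl)c4Cl)cc3)nc3[nH]ncc23)C1` is not yet measured; its change is (1-ethylpyrrolidin-3-yl)methyl in place of 1-methylazetidin-3-yl on an amide-type nitrogen. With compounds 1, 2 and 3 all at or close to that limit, compound 4 is expected near 2 nM (range 0.5 nM to 8 nM). The expected step of an at least 2.0-fold higher number from compound 3 to compound 4 (0.30 log units; that floor lies within the scatter) is therefore of no size beyond the scatter.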

Compound 4, half-maximal inhibitory concentration: < 1 nM
Compound 4: a limit, no number; the forecaster's own chance of this, stated with the estimate: 30%; middle value at least 2.0-fold (0.30 log units) from the limit.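

For the compounds shown here, the amide-type nitrogen also accommodates the larger (1-ethylpyrrolidin-3-yl)methyl, with 8 heavy atoms against 5 in 1-methylazetidin-3-yl and a methyl link to its ring, and inhibition in this assay still reaches the limit of the assay, giving a number no higher from compound 2 to compound 4 (the limit leaves the size open) as the only new step with a direction. None of the new steps can be sized, because the values pile up at one limit: the limit of < 1 nM in this assay, at which 3 of the 4 values shown sit.

Any ranking of these groups stays open, and so does how far the size of the group on this nitrogen can grow. As far as these compounds go, how a carboxylic acid or a hydroxyethyl chain would read there in this assay is also open.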